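The source may report more compounds than this note shows. Statements on the series, on what has been measured and on what is new or still open speak of the compounds shown alone.

Compound 3 `CCc1cc(C(C)=O)c(O)cc1OCCCCCCSC` gives 14% in an assay on isolated protein for binding affinity to leukotriene B4 receptor 1 (Homo sapiens), tested at 1 uM (a higher number here means more inhibition at the concentration tested (going by the name of the read-out), a lower number less inhibition), the lowest of the three numbers measured: compound 1 `CCc1cc(C(C)=O)c(O)cc1OCCCCC(C)(C)C#N` gives 30% and compound 2 `CCc1cc(C(C)=O)c(O)cc1OCCCC(C)(C)C(N)=O` gives 51%, so that a number 16 percentage points lower from compound 1 to compound 3 (beyond the scatter) and a number 37 percentage points lower from compound 2 to compound 3 (beyond the scatter), while a number 21 percentage points higher from compound 1 to compound 2 (beyond the scatter). Compound 4 `CCc1cc(C(C)=O)c(O)cc1OCCCCCC[S+](C)[O-]` differs from compound 3 by a group of 3 heavy atoms (1 carbon, 1 oxygen, 1 sulfur; no ring) in place of a group of 2 heavy atoms (1 carbon, 1 sulfur; no ring), on a saturated chain carbon, six bonds along the chain from an oxygen on an aromatic ring. Among the measured compounds shown here, none of the measured steps touches this sulfur-bearing part of the chain; they show only that exchanging the group carried on the chain shifts this assay by modest to large amounts in either direction. A modest rise is therefore expected, with compound 3 as the starting point, a number 14 percentage points higher from compound 3 to compound 4 (beyond the scatter). Compound 4 is accordingly estimated to give 28%, within a range from 10% to 48%.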

Compound 4, a percentage reported as inhibition, at one concentration (the size of the read-out at that concentration, not a potency): 50%
Estimate against measurement, compound 4: 22 percentage points below; the whole stated range lies below it.
By their numbers in this assay, from the lowest: compound 3; then compound 1; then compounds 4 and 2 (each within the scatter of the next).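

Six bonds along the chain from an oxygen on an aromatic ring, a group of 3 heavy atoms (1 carbon, 1 oxygen, 1 sulfur) in place of methylsulfanyl makes a large difference in this assay (a number 36 percentage points higher from compound 3 to compound 4 (beyond the scatter)). This single change removes any difference beyond the scatter from the amide-bearing compound (a number 1 percentage points lower from compound 2 to compound 4 (within the scatter)) and also clears the nitrile-bearing one (a number 20 percentage points higher from compound 1 to compound 4 (beyond the scatter)). Nothing shown here gives a reason for the rise.

As far as these compounds go, what a sulfone at this place would give remains open. So does the effect of a shorter or longer chain carrying the same sulfur group.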